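The compounds below may be only part of what the source reports. "The series", "measured", "known", "first", "only" and "open" are said of these compounds alone.

Measured compounds in a functional assay (trachea) with Cavia porcellus as the target; on this read-out lower numbers stand for stronger inhibition and higher numbers for weaker inhibition:
compound 1 `CCn1nc(-c2cccnc2)c2ccccc2c1=O` gives 1320 nM;
compound 2 `CCCCCCCCn1nc(-c2cccnc2)c2ccccc2c1=O` gives 21900 nM;
compound 3 `CC(=O)OCCn1nc(-c2cccnc2)c2ccccc2c1=O` gives 9770 nM.

Compound 3 stands second highest of the three numbers, nearer to compound 2 than to compound 1. Compound 4 `NCCn1nc(-c2cccnc2)c2ccccc2c1=O` differs from compound 3 by amino in place of acetoxy on a saturated chain carbon, two bonds along the chain from an aromatic nitrogen. Going by the values given here, two measured steps touch the same position: a 7.4-fold higher number from compound 1 to compound 3 (0.87 log units; beyond the scatter) and a 2.2-fold lower number from compound 2 to compound 3 (0.35 log units; beyond the scatter). Both show that a hydrogen at this place gives the lowest number and that removing the larger group from compound 2 lowers the number. The amino group is smaller than acetoxy, so a modest step downward is expected in this assay. Compound 4 is therefore estimated at 3500 nM, with a range from 900 nM to 13000 nM. That estimate corresponds to an expected step of a 2.8-fold lower number from compound 3 to compound 4 (0.45 log units; beyond the scatter).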

Compound 4, half-maximal inhibitory concentration: > 100000 nM
Compound 4: only a limit was reported; the forecaster's own chance of this, stated with the estimate: 10%; middle value at least 28-fold (1.45 log units) away from the limit.
By their numbers in this assay, from the lowest: compound 1; then compound 3; then compound 2. At a limit, above all of these: compound 4.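

In this assay compound 4 gives only a limit, > 100000 nM, not a number. Amino, with fewer heavy atoms than acetoxy, gives an at least 10-fold higher number from compound 3 to compound 4 (1.01 log units; beyond the scatter), and the other steps read an at least 4.5-fold higher number from compound 2 to compound 4 (0.65 log units; beyond the scatter) and an at least 75-fold higher number from compound 1 to compound 4 (1.87 log units; beyond the scatter). Among these four compounds, the number at this position therefore does not follow the heavy-atom count of the group, as the first three compounds alone might have suggested.

The compounds shown leave open how far compound 4 lies past its limit. They also leave open whether a hydroxyl, an acetamide or a dimethylamino group at this place would behave like amino or like acetoxy.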